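Solubility in a Chromane Sulfonamide Series

The source may hold more compounds than are shown below. What is called first, only, known or untested is meant among the compounds shown, and "the series" means these compounds.

Compound 1 `O=C1OCCN1c1cc(C(F)(F)F)ccc1[C@H]1CCOc2cc(S(=O)(=O)Nc3nccs3)ccc21` gives 295000 nM in a physicochemical assay for solubility (a higher number here means a more soluble compound, a lower number a less soluble compound), the highest of the three measured numbers. Compound 3 `O=S(=O)(Nc1ncccn1)c1ccc2c(c1)OCC[C@@H]2c1ccc(C(F)(F)F)cc1-c1ccc(F)cn1` gives 225000 nM, which lies within the scatter of compound 1, so no order between them is claimed. Compound 2 `Cc1ccc(-c2cc(C(F)(F)F)ccc2[C@H]2CCc3cc(S(=O)(=O)Nc4ncccn4)ccc32)cn1` gives 47000 nM, a number that falls beyond the scatter below compound 1.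

Compound 4 `Cc1nc(-c2cc(C(F)(F)F)ccc2[C@H]2CCOc3cc(S(=O)(=O)Nc4nccs4)ccc32)co1` differs from compound 1 by 2-methyl-1,3-oxazol-4-yl in place of 2-oxo-1,3-oxazolidin-3-yl on an aromatic carbon. Going by the values given here, no measured pair isolates this change. Compounds 2 and 3, which also carry aromatic groups at that position, show the lower numbers in the set, though compound 3 stays within the scatter of compound 1. The step from compound 1 to compound 4 is therefore expected to be a modest decrease, a 2.1-fold lower number from compound 1 to compound 4 (0.32 log units; beyond the scatter). Compound 4 is expected to give 140000 nM in this assay, with a range from 55000 nM to 320000 nM.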

Compound 4, solubility: 61000 nM
Compound 4: middle estimate off by 2.3-fold (0.36 log units), on the high side; low and high end bracket the measured number.
By their numbers in this assay, from the lowest: compounds 2 and 4 (each within the scatter of the next); then compounds 3 and 1 (each within the scatter of the next).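

Going by these compounds alone, the read-out in this assay shows a 4.8-fold lower number from compound 1 to compound 4 (0.68 log units; beyond the scatter) for a single change on this aromatic carbon, the first step in the set that isolates this position. The two groups have the same counts of heavy atoms, hydrogen-bond donors and acceptors, so those counts alone do not set the read-out at this position. Nothing at hand explains the step. On these data alone, whether it tracks the aromatic ring of the entering group stays open, as does where this assay would place an amine or a carboxylic acid on this aromatic carbon.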